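The compounds below may be only part of what the source reports. "The series", "measured", "known", "first", "only" and "open" are said of these compounds alone.

Measured compounds in a functional assay on HUVEC cells (Homo sapiens), read by scintillation counting and thymidine incorporation, with a stated time of 24 h; a lower number here means a stronger inhibitor, a higher number a weaker inhibitor:
compound 1 `CCC(C)n1ncn(-c2ccc(N3CCN(c4ccc(OC[C@@H]5CO[C@@](CC)(c6ccc(Cl)cc6Cl)O5)cc4)CC3)cc2)c1=O` gives 353 nM
compound 2 `CCC(C)n1ncn(-c2ccc(N3CCN(c4ccc(OC[C@@H]5CO[C@@](CBr)(c6ccc(Cl)cc6Cl)O5)cc4)CC3)cc2)c1=O` gives 569 nM
compound 3 `CCC(C)n1ncn(-c2ccc(N3CCN(c4ccc(OC[C@@H]5CO[C@@](CN6CCNCC6)(c6ccc(Cl)cc6Cl)O5)cc4)CC3)cc2)c1=O` gives 608 nM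

Compound 1 gives the lowest of the three numbers, but compound 2 and compound 3 both fall within the scatter of it: a 1.6-fold higher number from compound 1 to compound 2 (0.21 log units; within the scatter) and a 1.7-fold higher number from compound 1 to compound 3 (0.24 log units; within the scatter). The two substituted analogues also sit together, a 1.1-fold higher number from compound 2 to compound 3 (0.03 log units; within the scatter). Compound 4 `CCC(C)n1ncn(-c2ccc(N3CCN(c4ccc(OC[C@@H]5CO[C@@](Cn6ccnc6C(C)C)(c6ccc(Cl)cc6Cl)O5)cc4)CC3)cc2)c1=O` has not yet been measured in this assay; it differs from compound 1 by 2-isopropyl-1H-imidazol-1-yl in place of methyl on a saturated chain carbon bound to a saturated ring carbon. The same position carries bromo in compound 2 and piperazin-1-yl in compound 3, and neither change moved the number beyond the scatter, so a larger group at this position is expected to behave alike, a 1.4-fold higher number from compound 1 to compound 4 (0.15 log units; within the scatter), with no step beyond the scatter anticipated. Compound 4 is therefore estimated at 500 nM, in the range 200 nM to 1500 nM.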

Compound 4, half-maximal inhibitory concentration: 84 nM
For compound 4 the middle estimate is 6.0-fold (0.77 log units) above the measured one; the whole stated range lies above it.
By their numbers in this assay, from the lowest: compound 4; then compounds 1, 2 and 3 (each within the scatter of the next).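

This position does respond to its substituent: in this assay 2-isopropyl-1H-imidazol-1-yl in place of methyl gives a 4.2-fold lower number from compound 1 to compound 4 (0.62 log units; beyond the scatter) while bromo and piperazin-1-yl stay within the scatter of methyl. The same group also separates from both earlier replacements, with a 6.8-fold lower number from compound 2 to compound 4 (0.83 log units; beyond the scatter) and a 7.2-fold lower number from compound 3 to compound 4 (0.86 log units; beyond the scatter) at this one position. No supporting data shown here bear on why this group differs from the others.

Still open, going by these compounds, is whether the lower number depends on the imidazole ring or on its isopropyl group. An unsubstituted imidazol-1-yl or a 2-methylimidazol-1-yl at this position would separate the two.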